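The source may report more compounds than this note shows. Statements on the series, on what has been measured and on what is new or still open speak of the compounds shown alone.

In a functional assay on CWR22R cells (Homo sapiens) for cytotoxicity, read by MTT assay, with a stated time of 72 h (a higher number here means a weaker inhibitor, a lower number a stronger inhibitor), compound 1 `COc1cc(/C=C/C(=O)/C(=C/c2ccc3ccccc3n2)C(=O)/C=C/C2=C(C)CCCC2(C)C)ccc1O` gives 5100 nM and compound 2 `COc1cc(/C=C/C(O)=C/C(=O)/C=C/C2=C(C)CCCC2(C)C)ccc1O` gives 10600 nM in the same test. Compound 3 `COc1cc(/C=C/C(O)=C/C(=O)/C=C/C2=C(C)CCCC2(C)C)cc(OC)c1OC` reads 17100 nM on that scale. Compound 3 and compound 2 lie within the usual scatter of each other, so they cannot be told apart. Compound 3 does stand clearly above compound 1, with a gap beyond that scatter, and so it is the weaker inhibitor of that pair.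

Compound 4 `COc1cc(/C=C/C(O)=C/C(=O)/C=C/C2=C(C)CCCC2(C)C)cc(OC)c1O` keeps the frame of compound 3 with a single change: hydrogen in place of methyl on an oxygen on an aromatic ring with hydrogen in place of methyl on an oxygen on an aromatic ring, which turns methoxy to hydroxy. Within the data shown here, no measured pair isolates this change, so the data give no direct size for it. The nearest guide is compound 2 at 10600 nM which also carries a hydroxy on an aromatic ring. The expected step of a 1.7-fold lower number from compound 3 to compound 4 (0.23 log units; within the scatter) is therefore small, points toward a lower number and probably stays within the scatter. Compound 4 is estimated at 10000 nM with a range of 4500 nM to 21000 nM expected once it is measured.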

Compound 4, half-maximal inhibitory concentration: 12200 nM
For compound 4 the middle estimate is 1.2-fold (0.09 log units) below the measured one; the measured number falls inside the stated range.
By their numbers in this assay, from the lowest: compound 1; then compounds 2, 4 and 3 (each within the scatter of the next).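

In this assay, two single changes on the aromatic ring can now be sized directly: hydrogen in place of methyl on an oxygen on an aromatic ring gives a step (a 1.4-fold lower number from compound 3 to compound 4 (0.15 log units; within the scatter)), and methoxy in place of hydrogen on an aromatic carbon gives another (a 1.2-fold higher number from compound 2 to compound 4 (0.06 log units; within the scatter)). Both steps lie within the scatter, so in these three compounds neither turning a methoxy into a hydroxy nor adding a methoxy to the ring gives a detectable change in the reading. No supporting information is available here to explain this result.

The ring substituents shown are only hydroxy and methoxy. As far as these compounds go, it remains open whether a different group at these places, such as an amine, a carboxylic acid or the longer ethoxy, would shift the number beyond the scatter.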